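Dropping One Chloro from the Dichloro Core of Compound 2

This account rests on a few compounds, and the source may have more. Where it says the series, first, only, none or still open, it means among the compounds named here.

In a functional assay on SK-MEL-2 cells (Homo sapiens) for cytotoxicity, read by sulforhodamine B assay, with a stated time of 48 h (a higher number here means a weaker inhibitor of growth, a lower number a stronger inhibitor of growth), three compounds have been measured so far:

compound 1, `ClCc1ccc(Cn2cnc3c(Cl)ncnc32)cc1`: > 100000 nM (a limit of the assay, not a number)
compound 2, `ClCc1ccc(Cn2cnc3nc(Cl)nc(Cl)c32)cc1`: 2690 nM
compound 3, `ClCc1cccc(Cn2cnc3c(Cl)nc(Cl)nc32)c1`: 4460 nM

Compound 2 holds the lower of the two actual numbers, and compound 3 sits close enough that the two are within the usual scatter, so no order between them can be claimed. Compound 1 reports only a limit, as recorded in the limit of > 100000 nM in this assay, at which 1 of the 3 values shown sits.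

Compound 4, `ClCc1ccc(Cn2cnc3ncnc(Cl)c32)cc1`, differs from compound 2 in one place: hydrogen in place of chloro on an aromatic carbon. Among the measured compounds shown here, no pair of measured compounds shows this exact step, so its size can only be estimated. Like compound 4, compound 1 carries a single chloro on the core; compound 1 gives > 100000 nM. On that basis the step from compound 2 to compound 4 is expected to weaken growth inhibition, raising the number by a 5.6-fold higher number from compound 2 to compound 4 (0.75 log units; beyond the scatter) in this assay, clearly beyond the scatter. Compound 4 is accordingly estimated at 15000 nM, with a likely range from 4000 nM to 80000 nM.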

Compound 4, concentration for total growth inhibition: > 100000 nM
Compound 4: a limit, no number; the forecaster's own chance of this, stated with the estimate: 25%; at least 6.6-fold (0.82 log units) between middle value and limit.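

In this assay, among the compounds shown here, hydrogen in place of chloro on the aromatic carbon between two ring nitrogen atoms gives an at least 37-fold higher number from compound 2 to compound 4 (1.57 log units; beyond the scatter), which is beyond the scatter and is the first step here between measured compounds that differ in one place. For the compounds shown here, this shows that growth inhibition depends on the chloro at this position, which the earlier compounds could not show on their own. The value of compound 4 is a limit, so the step gives only the smallest possible size of the loss, and the compound joins compound 1 at the same limit: the limit of > 100000 nM in this assay, at which 2 of the 4 values shown sit.

From the compounds shown here alone, it remains open whether another group on this carbon, such as an amine or a methoxy group, could stand in for the chloro. Also open, going by these compounds, is how the chloromethyl group contributes, for instance against a hydroxymethyl group at the same place.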